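Replacing the Nitro Group with Amino on Compound 2

The source may report more compounds than this note shows. Statements on the series, on what has been measured and on what is new or still open speak of the compounds shown alone.

Measured compounds:
compound 1, `CNc1nc(Nc2ccc(C)c([N+](=O)[O-])c2)ncc1C(=O)Nc1cc(NC(=O)c2cccc(C(F)(F)F)c2)ccc1C`, 52 nM
compound 2, `CNc1nc(Nc2ccc(C)c([N+](=O)[O-])c2)ncc1C(=O)Nc1cc(NC(=O)c2cccc(OC)c2)ccc1C`, 480 nM

In a functional assay on K562 cells (Homo sapiens) for antiproliferative activity, read by CellTiter-Glo and CCK-8 assay, with a stated time of 72 h (on this read-out lower numbers stand for stronger inhibition of growth and higher numbers for weaker inhibition of growth), compound 1 gives 52 nM, and compound 2 gives 480 nM. For the measured compounds named here, compound 2 thus holds the higher of the two numbers, and the single measured step, a 9.2-fold higher number from compound 1 to compound 2 (0.97 log units; beyond the scatter), is what separates them.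

Compound 3 `CNc1nc(Nc2ccc(C)c(N)c2)ncc1C(=O)Nc1cc(NC(=O)c2cccc(OC)c2)ccc1C` differs from compound 2 in one place: amino in place of nitro on an aromatic carbon. Going by the values given here, no measured step involves this change; the only step on record, a 9.2-fold higher number from compound 1 to compound 2 (0.97 log units; beyond the scatter), concerns a different group on a different ring, so it offers no guide to the size or direction of this one. With nothing to lean on, the estimate for compound 3 is kept close to compound 2 and given a wide range. Compound 3 is therefore expected to give about 500 nM, within 100 nM to 3000 nM. The expected step is a 1.0-fold higher number from compound 2 to compound 3 (0.02 log units; within the scatter), with low confidence.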

Compound 3, concentration for 50% growth inhibition: 330 nM
Beside the measured number, compound 3's estimate is 1.5-fold (0.18 log units) above it, within the range that was stated.
By their numbers in this assay, from the lowest: compound 1; then compounds 3 and 2 (each within the scatter of the next).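

In this assay the exchange of nitro for amino on the aromatic carbon ortho to a methyl group gives a 1.5-fold lower number from compound 2 to compound 3 (0.16 log units; within the scatter) and so makes no clear difference to growth inhibition. For the compounds shown here, this is the first sign that this position can carry either group, at least in compounds with methoxy on the other end of the molecule, whereas the earlier step spoke only of a different group on a different ring. Nothing measured here shows why the two groups read alike.

The compounds shown leave open whether amino would behave the same way alongside the trifluoromethyl group of compound 1. They also leave open how other groups at this position, such as a hydroxyl, an acetamide or a chlorine atom, would read.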